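Swapping a benzoyl for a cyano on a sulfonyl alkene

The source may hold more compounds than are shown below. What is called first, only, known or untested is meant among the compounds shown, and "the series" means these compounds.

Of the compounds shown here, three sharing one core have been tested in a functional assay on KM12 cells (Homo sapiens) for inhibition, read by sulforhodamine B assay, with a stated time of 48 h; on this read-out higher numbers stand for weaker inhibition of growth and lower numbers for stronger inhibition of growth. Compound 1 `COc1ccc(-c2[nH]c3ccccc3c2/C=C(\C#N)S(=O)(=O)c2ccccc2)cc1` gives 374 nM. Compound 2 `CCOC(=O)C(=Cc1c(-c2ccccc2)[nH]c2ccccc12)C(=O)OCC` gives 3500 nM. Compound 3 `O=C(/C(=C\c1c(-c2ccccc2)[nH]c2ccccc12)S(=O)(=O)c1ccccc1)c1ccccc1` gives 5100 nM, the highest of the three numbers, although the number for compound 2 lies within the scatter of it, so the two cannot be ranked; only compound 1 stands clearly apart from compound 3, with a number beyond the scatter.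

Compound 4 `N#C/C(=C\c1c(-c2ccccc2)[nH]c2ccccc12)S(=O)(=O)c1ccccc1` is compound 3 with one change: cyano in place of benzoyl on a double-bonded chain carbon bound to a double-bonded chain carbon and a sulfonyl sulfur. Among the measured compounds shown here, no measured pair in this set shows exactly this swap, so its effect cannot be read off directly. What the set does offer is compound 1, which carries the same cyano group on the same double-bonded chain carbon and differs from compound 4 only in a methoxy on its pendant ring; because compound 1 gives 374 nM, compound 4 is expected to land nearer that number than the number for compound 3. The step from compound 3 to compound 4 is therefore estimated as a 7.3-fold lower number from compound 3 to compound 4 (0.86 log units; beyond the scatter), a drop beyond the scatter. Compound 4 is expected to give about 700 nM in this assay, within a range from 250 nM to 2500 nM.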

Compound 4, concentration for 50% growth inhibition: 652 nM
For compound 4 the middle estimate is 1.1-fold (0.03 log units) above the measured one, within the range that was stated.
By their numbers in this assay, from the lowest: compounds 1 and 4 (each within the scatter of the next); then compounds 2 and 3 (each within the scatter of the next).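

In this assay, cyano in place of benzoyl on a double-bonded chain carbon bound to a double-bonded chain carbon and a sulfonyl sulfur gives a 7.8-fold lower number from compound 3 to compound 4 (0.89 log units; beyond the scatter) for this one change, so this position clearly matters for the read-out. The pair with compound 1 adds a second finding: hydrogen in place of methoxy on an aromatic carbon gives a 1.7-fold higher number from compound 1 to compound 4 (0.24 log units; within the scatter) and leaves these two compounds unranked, so that methoxy makes no readable difference on the cyano compounds. The swap replaces 8 heavy atoms and an aromatic ring with 2 heavy atoms and no ring, but no measurement here shows which of these differences, if either, accounts for the step.

From the compounds shown here alone, only benzoyl and cyano can be compared directly at this position, so it remains open where a carboxylic acid, an amide or a small chain such as methyl would fall on the same carbon. Going by these compounds, it also remains open whether an amine or a fluorine in place of the methoxy on that aromatic carbon would leave the number just as unchanged.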